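Swapping a cyclohexyl for pyrazin-2-yl on the piperazine nitrogen

A few compounds are considered here, and "the series" means these few. Any claim that something is new, unique, unknown or untested is made for them only; others in the source may bear on it.

Compound 3 `Nc1ccccc1NC(=O)c1ccc(CSC(=S)N2CCN(C3CCCCC3)CC2)cc1` was tested in a functional assay on HeLa cells (Homo sapiens) for antiproliferative activity, read by CCK-8 assay, with a stated time of 72 h, tested at 2 uM (a lower number here means a weaker effect, a higher number a stronger effect of the compound at the concentration tested), and gave 30.6%, the second highest of three numbers: compound 1 `Nc1ccccc1NC(=O)c1ccc(CSC(=S)N2CCN(Cc3ccccn3)CC2)cc1` gave 14.2%, compound 2 `Nc1ccccc1NC(=O)c1ccc(CSC(=S)N2CCN(Cc3cccnc3)CC2)cc1` gave 69.7%. Compound 4 `Nc1ccccc1NC(=O)c1ccc(CSC(=S)N2CCN(c3cnccn3)CC2)cc1` differs from compound 3 by pyrazin-2-yl in place of cyclohexyl on an amine nitrogen in a ring. Two measured steps also alter this ring nitrogen: a number 16.4 percentage points higher from compound 1 to compound 3 (beyond the scatter) and a number 39.1 percentage points lower from compound 2 to compound 3 (beyond the scatter), so changing this group can move the read-out in either direction by a large amount. Among the compounds with values here, no measured step puts an aromatic ring directly on that nitrogen, so the direction is uncertain. The estimate for compound 4 is therefore 35%, within 12% to 62%, a step of a number 4.4 percentage points higher from compound 3 to compound 4 (within the scatter) expected to stay near the scatter.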

Compound 4, a percentage reported as inhibition, at one concentration (the size of the read-out at that concentration, not a potency): 70.4%
Beside the measured number, compound 4's estimate is 35.4 percentage points below it; measured number above the stated range.
By their numbers in this assay, from the lowest: compound 1; then compound 3; then compounds 2 and 4 (each within the scatter of the next).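

Setting an aromatic ring directly on the ring nitrogen can give a strong effect in this assay: the change brings a number 39.8 percentage points higher from compound 3 to compound 4 (beyond the scatter) and a number 56.2 percentage points higher from compound 1 to compound 4 (beyond the scatter). The linking chain carbon is also not required for this level of effect, since pyrazin-2-yl and (pyridin-3-yl)methyl stand level, with a number 0.7 percentage points higher from compound 2 to compound 4 (within the scatter). Nothing available explains these steps.

Going by these compounds, it remains open whether the ring nitrogens of pyrazin-2-yl matter, as a directly attached phenyl would test. A (pyrazin-2-yl)methyl group would show how the chain carbon acts with this ring.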